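The source may report more compounds than this note shows. Statements on the series, on what has been measured and on what is new or still open speak of the compounds shown alone.

Measured so far:
- compound 1, `Nc1ncnc2c1c(-c1cnc3[nH]ccc3c1)nn2CCCC(=O)NO`: in a functional assay on CNE-2 cells (Homo sapiens) for inhibition, read by MTT assay, with a stated time of 72 h (a higher number here means a weaker inhibitor, a lower number a stronger inhibitor), compound 1 gives > 150000 nM, which is a limit of the assay and not a number.
- compound 2, `Nc1ncnc2c1c(-c1cnc3[nH]ccc3c1)nn2CCCCCC(=O)NO`: in this assay compound 2 gives > 50000 nM, again a limit rather than a number.

Compound 2 thus stands at a limit only, as the limit of > 50000 nM in this assay, at which 1 of the 2 values shown sits, shows; compound 1 sits at a limit as well, (the limit of > 150000 nM in this assay, at which 1 of the 2 values shown sits). Within the data shown here, the single measured step, a step that the two limits leave unreadable from compound 1 to compound 2, has no readable size because both ends are limits.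

Compound 3, `Nc1ncnc2c1c(-c1cnc3[nH]ccc3c1)nn2CCCCCCCCC(=O)NO`, is not yet measured. It differs from compound 2 by 3-(hydroxycarbamoyl)propyl in place of hydroxycarbamoyl on a saturated chain carbon, five bonds along the chain from an aromatic nitrogen. Among the measured compounds shown here, the one measured step bears on this change but gives no size and no direction, so no movement beyond the scatter can be argued either way, and a further limit is the most likely outcome. Compound 3 is therefore expected at 40000 nM, with a range from 5000 nM to 200000 nM. The step this estimate means, an at least 1.2-fold lower number from compound 2 to compound 3 (0.09 log units; that floor lies within the scatter), is an expectation only.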

Compound 3, half-maximal inhibitory concentration: 2270 nM
Beside the measured number, compound 3's estimate is 18-fold (1.25 log units) above it; measured number outside the range, below it.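

Among these compounds, on a saturated chain carbon, lengthening the chain that carries the hydroxycarbamoyl end gives the first readable number of the series in this assay, with an at least 22-fold lower number from compound 2 to compound 3 (1.34 log units; beyond the scatter) and an at least 66-fold lower number from compound 1 to compound 3 (1.82 log units; beyond the scatter), while the step between the two shorter chains cannot be read. Compound 1 stands at a limit of the assay and not at a number, which makes the step from it a floor: the limit of > 150000 nM in this assay, at which 1 of the 3 values shown sits. Compound 2 also stands at a limit of the assay and not at a number, so the step from it is a floor too: the limit of > 50000 nM in this assay, at which 1 of the 3 values shown sits.

As far as these compounds go, whether a longer chain than that of compound 3 lowers the number further stays open. So does whether a carboxylic acid or an amine at the chain end in place of hydroxycarbamoyl would keep the number of compound 3.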